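A few compounds are considered here, and "the series" means these few. Any claim that something is new, unique, unknown or untested is made for them only; others in the source may bear on it.

Compound 1 `CC#CCC(O)(c1ccc(N2CCN(S(=O)(=O)c3ccc(N)nc3)C[C@@H]2C#CC)cc1)C(F)(F)F` stands at the top of the three numbers recorded so far: in an ADME assay (liver) for metabolic stability, with Liver microsome (Rattus norvegicus) as the target, using microsomes and NADPH, with a stated time of 30 min (on this read-out higher numbers stand for fast clearance and lower numbers for slow clearance), compound 1 gives 115 mL.min-1.g-1. Compound 2 `CC#C[C@H]1CN(S(=O)(=O)c2ccc(N)nc2)CCN1c1ccc(S(=O)(=O)NC)cn1` gives 42 mL.min-1.g-1 in this assay, and compound 3 `CC#C[C@H]1CN(S(=O)(=O)c2ccc(N)nc2)CCN1c1ncc(C(O)(C(F)(F)F)C(F)(F)F)s1` gives 34 mL.min-1.g-1, both beyond the scatter below compound 1. Compound 4 `C#CCC(O)(c1ccc(N2CCN(S(=O)(=O)c3ccc(N)nc3)C[C@@H]2C#CC)cc1)C(F)(F)F` has not yet been measured. It differs from compound 1 in a single place: hydrogen in place of methyl on a triple-bonded carbon. Within the data shown here, no pair of measured compounds traces this exchange, so no step of known size is at hand. The step of a 1.2-fold lower number from compound 1 to compound 4 (0.08 log units; within the scatter) is expected to stay within the scatter, with no clear direction either way. Compound 4 is therefore estimated at 95 mL.min-1.g-1 in this assay, with a range from 50 mL.min-1.g-1 to 180 mL.min-1.g-1.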

Compound 4, intrinsic clearance in microsomes: 59 mL.min-1.g-1
Compound 4: middle estimate off by 1.6-fold (0.21 log units), on the high side, within the range that was stated.
By their numbers in this assay, from the lowest: compounds 3, 2, 4 and 1 (each within the scatter of the next, the first and the last beyond it).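

In this assay, the exchange of hydrogen for methyl on this triple-bonded carbon, which turns the but-2-yn-1-yl chain into a propargyl chain, gives a 1.9-fold lower number from compound 1 to compound 4 (0.29 log units; within the scatter). Among these compounds, at this one place, then, removing the methyl leaves the read-out within the usual scatter, which the earlier compounds could not show. No measurement is at hand that bears on the reason for this result. Still open, on these data alone, is whether a larger group on this carbon, such as a longer chain, a phenyl group or an amine, would move the number beyond the scatter.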